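Smaller Ring on an Acid That Shows No Effect

The source may report more compounds than this note shows. Statements on the series, on what has been measured and on what is new or still open speak of the compounds shown alone.

Compound 1 `COC(=O)c1ccc(OCCCCOc2ccc(C(=O)CC3CCCC3)c(O)c2C)cc1`, compound 2 `Cc1c(OCCCCOc2ccc(C(=O)O)cc2F)ccc(C(=O)CC2CCCC2)c1O` and compound 3 `Cc1c(OCCCCOc2ccccc2C(=O)O)ccc(C(=O)CC2CCCC2)c1O` share a core in which a ketone bearing a cyclopentyl group sits on one aromatic ring, joined by a flexible ether chain to a second aromatic ring that carries a carboxylic acid or its methyl ester. In an assay on HEK293 cells for positive allosteric modulation of metabotropic glutamate receptor 3 (Rattus norvegicus), read by thallium flux, with a stated time of 2.5 min (a higher number here means that more compound is needed for the effect, a lower number that less compound is needed), compound 1 gives "not determined" (no result reported). Compound 3 likewise gives "not determined" (no result reported) in this assay. For compound 2 this assay reports a limit of > 10000 nM rather than a single number. That limit is the edge described as the limit of > 10000 nM in this assay, at which 1 of the 3 values shown sits, so the standing of compound 2 is known only as lying at that edge.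

Compound 4 `Cc1c(OCCCCOc2ccc(C(=O)O)cc2F)ccc(C(=O)CC(C)C)c1O` differs from compound 2 in one place: isopropyl in place of cyclopentyl on a saturated chain carbon bound to a carbonyl carbon. Among the measured compounds shown here, no step between two measured compounds is available here to calibrate a change of this kind, and the acid and the fluorine on the second ring stay as they are in compound 2. The expectation is that compound 4 remains at the edge of what this assay reports, with an estimated step that the limit leaves unreadable from compound 2 to compound 4, none beyond the scatter. Compound 4 is therefore estimated at 15000 nM, within a range of 7000 nM to 40000 nM, most likely returned again only as a limit.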

Compound 4, half-maximal effective concentration: 1420 nM
Beside the measured number, compound 4's estimate is 11-fold (1.02 log units) above it, outside the stated range (below it).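

In this assay, the group on a saturated chain carbon bound to a carbonyl carbon turns out to matter: isopropyl in place of cyclopentyl gives an at least 7.0-fold lower number from compound 2 to compound 4 (0.84 log units; beyond the scatter). Among the compounds shown here, none of the earlier compounds had returned a single number, so compound 4 is the first here to give a readable result, and it does so with the acid and the fluorine on the second ring unchanged. The real size of the step remains unknown because the result for compound 2 is a limit and not a number: the limit of > 10000 nM in this assay, at which 1 of the 4 values shown sits.

This one pair cannot separate the loss of the ring from the smaller number of carbons, since the two change together, and a cyclopropyl or a tert-butyl group at the same place would help to tell these apart. From the compounds shown here alone, compound 1 and compound 3 have no reported result, so steps involving them cannot be read, and it stays open whether isopropyl would have the same effect with the methyl ester of compound 1 or with the acid placement of compound 3.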